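Notes on the heteroaryl swap and microsomal stability

This account rests on a few compounds, and the source may have more. Where it says the series, first, only, none or still open, it means among the compounds named here.

Compound 1 `CC(C)C(c1ccc(-c2ccc3cccc(F)c3c2)[nH]c1=O)N1CCN/C1=N\C#N` is the point of departure. In an ADME assay on microsomes from liver (Mus musculus) for metabolic stability (on this read-out higher numbers stand for a longer-lived compound and lower numbers for a shorter-lived compound), compound 1 gives 0.207 h, the lowest of the two numbers available in this assay. Compound 2 `CCC(CC)(c1nnc[nH]1)c1ccc(-c2ccc3cccc(F)c3c2)[nH]c1=O` shares the core, and in this assay compound 2 gives 0.447 h, a figure that sits beyond the usual scatter above compound 1. Compound 3 `CCn1ncc2c(F)cc(-c3ccc(C(CC)(CC)c4nnc[nH]4)c(=O)[nH]3)cc21` reaches only a limit in this assay. In this assay compound 3 gives > 3 h, which is a limit of the assay rather than a number, as recorded in the limit of > 3 h in this assay, at which 1 of the 3 values shown sits.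

Compound 4 `CC(C)C(c1cnc(N)s1)c1ccc(-c2ccc3cccc(F)c3c2)[nH]c1=O` has not yet been measured in this assay. It differs from compound 1 in a single place: a group of 6 heavy atoms (3 carbon, 2 nitrogen, 1 sulfur; one five-membered aromatic ring with 2 hetero atoms) in place of a group of 8 heavy atoms (4 carbon, 4 nitrogen; one five-membered non-aromatic ring with 2 hetero atoms), on a saturated chain carbon bound to an aromatic carbon and a saturated chain carbon. Among the compounds with values here, no pair of measured compounds carries this same change, so there is no measured step to anchor it, and the two numbers plus one limit available do not bear on it directly. The expected step from compound 1 to compound 4 in this assay is small, a 1.4-fold higher number from compound 1 to compound 4 (0.16 log units; within the scatter), and not clearly beyond the scatter in either direction. Compound 4 is therefore estimated to give 0.3 h in this assay, with a range from 0.1 h to 0.9 h.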

Compound 4, half-life: 0.08 h
Beside the measured number, compound 4's estimate is 3.8-fold (0.57 log units) above it, and the stated range ends above it.
By their numbers in this assay, from the lowest: compound 4; then compound 1; then compound 2. At a limit, above all of these: compound 3.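

At the saturated chain carbon bound to an aromatic carbon and a saturated chain carbon, the choice of group does register in this assay: putting 2-amino-1,3-thiazol-5-yl in place of the group of 8 heavy atoms with its five-membered non-aromatic ring gives a 2.6-fold lower number from compound 1 to compound 4 (0.41 log units; beyond the scatter). Within the data shown here, this is the first step that can be read at this place, and it shows that a five-membered aromatic ring with 2 hetero atoms does not lengthen the half-life on this core, but shortens it; as a single pair, it sets no general pattern. No measurement shown accounts for the size or direction of this step.

As far as these compounds go, whether the step belongs to the aromatic ring or to its amine stays open, and a plain 1,3-thiazol-5-yl group or a methyl group in place of the amine at this same carbon-bound ring would separate the two. Also open, from the compounds shown here alone, is whether the same change keeps its size on a core other than that of compound 1.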